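The source may report more compounds than this note shows. Statements on the series, on what has been measured and on what is new or still open speak of the compounds shown alone.

Within the data shown here, in a functional assay on NALM-6 cells (Homo sapiens) for antiproliferative activity, read by MTT assay and trypan blue exclusion, with a stated time of 72 h (on this read-out higher numbers stand for weaker inhibition and lower numbers for stronger inhibition), compound 2 (`COC(=O)c1ccc(C2SCC(=O)N2c2ccc(N3CCN(S(=O)(=O)c4ccccc4)CC3)cn2)c(OC)c1`) gives 48400 nM, the only exact number so far. Compound 1 (`COC(=O)c1ccc(C2SCC(=O)N2c2ccc(N3CCN(S(=O)(=O)c4ccc(F)cc4)CC3)cn2)c(OC)c1`) reads > 100000 nM, which is a limit of the assay and not a number. Compound 3 (`COC(=O)c1ccc(C2SCC(=O)N2c2ccc(N3CCN(S(=O)(=O)c4ccc(OC)cc4)CC3)cn2)c(OC)c1`) differs from compound 2 in one place: methoxy in place of hydrogen on an aromatic carbon, para to a large group (methoxy in place of hydrogen on an aromatic carbon). Among the measured compounds shown here, one measured step bears on this change, and it involves the same place: hydrogen in place of fluoro gave an at least 2.0-fold lower number from compound 1 to compound 2 (0.31 log units; beyond the scatter). Fluoro is not methoxy, and that step has only one firm end, so it offers a direction rather than a size. The new group in compound 3 is therefore expected to weaken inhibition modestly, with an estimated 1.2-fold higher number from compound 2 to compound 3 (0.09 log units; within the scatter). Compound 3 is expected at 60000 nM, with an estimated range from 25000 nM to 100000 nM.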

Compound 3, half-maximal inhibitory concentration: 29400 nM
Compound 3: the middle estimate sits 2.0-fold (0.31 log units) above what was measured; the range from low to high includes it.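

Methoxy in place of hydrogen on this aromatic carbon gave a 1.6-fold lower number from compound 2 to compound 3 (0.22 log units; within the scatter), so in this assay the ring carries methoxy here with no difference from hydrogen that can be told apart. Methoxy in place of fluoro at the same carbon gave an at least 3.4-fold lower number from compound 1 to compound 3 (0.53 log units; beyond the scatter), so compound 1, with fluoro, stands apart from both compound 2 and compound 3. The true size of that gap stays unknown, since the value for compound 1 is a limit and not a number: the limit of > 100000 nM in this assay, at which 1 of the 3 values shown sits.

As far as these compounds go, it remains open whether the fluoro result is particular to fluoro or would be shared by a chloro group or a nitrile at this place. From the compounds shown here alone, it is equally open whether an amine, a carboxylic acid or a longer chain such as butoxy would read like methoxy or like fluoro.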